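Swapping the anilide substituent: from dimethylphenyl to chlorophenyl

The compounds below may be only part of what the source reports. "The series", "measured", "known", "first", "only" and "open" are said of these compounds alone.

Measured compounds:
Compound 1, `Cc1ccc(NC(=O)/C=C/C(=O)N2C/C(=C\c3ccccc3)C(=O)/C(=C/c3ccccc3)C2)cc1`: 1100 nM
Compound 2, `Cc1ccc(NC(=O)/C=C/C(=O)N2C/C(=C\c3ccccc3)C(=O)/C(=C/c3ccccc3)C2)cc1C`: 7100 nM

Among the measured compounds shown here, in a functional assay on CCRF-CEM cells (Homo sapiens) for cytotoxicity (on this read-out higher numbers stand for weaker inhibition and lower numbers for stronger inhibition), compound 2 gives 7100 nM, the higher of the two numbers; the only neighbour is compound 1, reached by a 6.5-fold higher number from compound 1 to compound 2 (0.81 log units; beyond the scatter). Compound 3, `O=C(/C=C/C(=O)N1C/C(=C\c2ccccc2)C(=O)/C(=C/c2ccccc2)C1)Nc1ccc(Cl)cc1`, has not yet been measured in this assay. It differs from compound 2 by 4-chlorophenyl in place of 3,4-dimethylphenyl on an amide-type nitrogen. For the measured compounds named here, the one measured step bears on this in reverse: it went from compound 1 to compound 2 by adding a methyl on an aromatic carbon, and going to compound 3 removes that methyl again while trading the other for a chlorine. The step from compound 2 to compound 3 is therefore expected to be a 5.9-fold lower number from compound 2 to compound 3 (0.77 log units; beyond the scatter), landing near where compound 1 already stands. Compound 3 is thus expected to give about 1200 nM in this assay, within a range of 400 nM to 4000 nM.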

Compound 3, half-maximal inhibitory concentration: 840 nM
Estimate against measurement, compound 3: 1.4-fold (0.15 log units) above, and the stated range covers the measured number.
By their numbers in this assay, from the lowest: compounds 3 and 1 (each within the scatter of the next); then compound 2.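

In this assay, 4-chlorophenyl in place of 3,4-dimethylphenyl on the amide-type nitrogen gives an 8.5-fold lower number from compound 2 to compound 3 (0.93 log units; beyond the scatter) and so recovers the whole of the loss seen with the added methyl. Chloro in place of methyl gives a 1.3-fold lower number from compound 1 to compound 3 (0.12 log units; within the scatter) and does not separate the two groups, so among these three compounds only the 3,4-dimethylphenyl of compound 2 stands apart. Nothing at hand explains why the second methyl counts for so much while the exchange of methyl for chloro does not.

On these data alone, what remains open is whether the unsubstituted phenyl, 4-bromophenyl or 4-methoxyphenyl on the same nitrogen would stay with compound 1 and compound 3. As far as these compounds go, it is also open whether a 3,4-dichlorophenyl would follow compound 2, which would show whether that gap goes with the methyl itself or with carrying two substituents.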